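Amino-thiadiazole swap on a chromone-methylthio scaffold

This account rests on a few compounds, and the source may have more. Where it says the series, first, only, none or still open, it means among the compounds named here.

Measured so far:
compound 1 `Cc1nnc(SCc2cc(=O)c3ccccc3o2)o1`: > 25000 nM
compound 2 `Nc1nnc(SCc2cc(=O)c3ccccc3o2)s1`: > 25000 nM
compound 3 `Cc1nnc(SCc2coc3ccccc3c2=O)o1`: 790 nM

In a functional assay on SW480 cells (Homo sapiens) for cytotoxicity, read by MTT assay, with a stated time of 72 h (a lower number here means a stronger inhibitor, a higher number a weaker inhibitor), compound 1 gives only a limit, > 25000 nM. Compound 2 likewise gives only a limit, > 25000 nM. Among the compounds with values here, compound 3 is the one compound with a number in this assay, 790 nM. Compound 3 and compound 1 have the same atoms joined differently; the difference between the two cores is not broken down here.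

The change from compound 1 to compound 2 is 5-amino-1,3,4-thiadiazol-2-yl in place of 5-methyl-1,3,4-oxadiazol-2-yl on a sulfur. Its step, a step that the two limits leave unreadable from compound 1 to compound 2, cannot be sized, because the limit of > 25000 nM in this assay, at which 2 of the 3 values shown sit, hides both values.

Compound 4 `Nc1nnc(SCc2coc3ccccc3c2=O)s1` is not yet measured. It differs from compound 3 by the same change, (5-amino-1,3,4-thiadiazol-2-yl in place of 5-methyl-1,3,4-oxadiazol-2-yl on a sulfur). Since the earlier step is unreadable, there is nothing to carry over, and the expected step from compound 3 to compound 4 is taken as roughly flat, a 1.9-fold higher number from compound 3 to compound 4 (0.28 log units; within the scatter), resting only on the number for compound 3, 790 nM. Compound 4 is therefore estimated at 1500 nM, with a wide range from 300 nM to 10000 nM.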

Compound 4, half-maximal inhibitory concentration: > 25000 nM
Compound 4: no number, only a limit; the forecaster's own chance of this, stated with the estimate: 25%; middle value at least 16-fold (1.22 log units) from the limit.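

In this assay, putting 5-amino-1,3,4-thiadiazol-2-yl in place of 5-methyl-1,3,4-oxadiazol-2-yl on the sulfur of the core of compound 3 gives an at least 31-fold higher number from compound 3 to compound 4 (1.50 log units; beyond the scatter), a large step that lies beyond the usual scatter. Compound 4 gives > 25000 nM, which is a limit of the assay and not a number. The result therefore shows that the change costs much on this one core, but it does not show whether the change would do the same on the core of compound 1, where the step cannot be read, and so nothing can be said about carrying it from one core to the other, because both values there are hidden: the limit of > 25000 nM in this assay, at which 3 of the 4 values shown sit.

Within the data shown here, the one readable step alters the ring atoms and the group on the ring together, so it does not separate the two. From the compounds shown here alone, whether 5-methyl-1,3,4-thiadiazol-2-yl or 5-amino-1,3,4-oxadiazol-2-yl on the same sulfur would behave more like compound 3 or more like compound 4 remains open.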